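A few compounds are considered here, and "the series" means these few. Any claim that something is new, unique, unknown or untested is made for them only; others in the source may bear on it.

Measured so far in a functional assay on HeLa cells (Homo sapiens) for antiproliferative activity, with a stated time of 48 h; a lower number here means a stronger inhibitor, a higher number a weaker inhibitor:
- compound 1 `C=C(Br)C(=O)Nc1ccc(/C=C/C(=O)c2ccc(Cl)c(Cl)c2)cc1` gives 3200 nM
- compound 2 `C=C(Br)C(=O)Nc1ccc(/C=C/C(=O)c2cccs2)cc1` gives 340 nM

Of these two, compound 1 at 3200 nM has the higher number and is the weaker inhibitor in this assay by a margin beyond the scatter.

The next compound to consider is compound 3 `Nc1ccc(/C=C/C(=O)c2ccc(Cl)c(Cl)c2)cc1` which has hydrogen in place of (1-bromoethenyl)carbonyl on a nitrogen on an aromatic ring.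

Among the measured compounds shown here, only one measured step is available, a 9.4-fold lower number from compound 1 to compound 2 (0.97 log units; beyond the scatter) and it replaces 3,4-dichlorophenyl with thiophen-2-yl on a carbonyl carbon. That is a different place in the molecule, so this step bears on the change only indirectly. It shows that the series can move by a modest but real amount on a single change. For the measured compounds named here, no measured compound lacks the (1-bromoethenyl)carbonyl group, so neither the size nor the direction of its loss is measured.

Since a whole group is lost, a step of similar size is a reasonable guess. The expected change is a 3.8-fold higher number from compound 1 to compound 3 (0.57 log units; beyond the scatter) towards a weaker inhibitor, with considerable uncertainty. Compound 3 is estimated at 12000 nM with 3000 nM to 40000 nM as the expected range.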

Compound 3, half-maximal inhibitory concentration: 31000 nM
Compound 3: the middle estimate sits 2.6-fold (0.41 log units) below what was measured; the measured number falls inside the stated range.
By their numbers in this assay, from the lowest: compound 2; then compound 1; then compound 3.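

In this assay, taking the (1-bromoethenyl)carbonyl group off the nitrogen on the aromatic ring, which leaves a free amino group, gives a 9.7-fold higher number from compound 1 to compound 3 (0.99 log units; beyond the scatter). This position now has a measured step of its own, beyond the scatter and towards a weaker inhibitor, with the 3,4-dichlorophenyl group held constant, and the step is similar in size to the earlier change on the carbonyl carbon, though opposite in direction. Nothing at hand accounts for this loss, and no supporting data bear on it.

The compounds shown leave open which part of the departing group carries the difference: an acetyl group or a plain propenoyl group on the same nitrogen would separate the contribution of the bromine and the double bond from that of the amide carbonyl, and a 1-chloroethenyl carbonyl group would test the halogen alone. It also remains open whether the same loss appears with the thiophen-2-yl group of compound 2 in place of the 3,4-dichlorophenyl group, since the free amino group is shown only alongside the latter.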